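Swapping One Halogen for Another on the Benzamide Arm

This account rests on a few compounds, and the source may have more. Where it says the series, first, only, none or still open, it means among the compounds named here.

For the measured compounds named here, compound 2, `O=C(NC(=S)NNc1ncnc2ccccc12)c1ccc(F)cc1`, is the only measured compound to give a number in a functional assay on KB cells (Homo sapiens) for cytotoxicity, read by MTT assay, with a stated time of 72 h; on this read-out higher numbers stand for weaker inhibition and lower numbers for stronger inhibition: compound 2 gives 1870 nM. Compound 1, `COc1ccccc1C(=O)NC(=S)NNc1ncnc2ccccc12`, gives only a limit in this assay, namely > 50000 nM. On these data alone, the step of an at least 26-fold lower number from compound 1 to compound 2 (1.42 log units; beyond the scatter) is large, and with compound 1 sitting at the limit of > 50000 nM in this assay, at which 1 of the 2 values shown sits, its full size stays open.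

Compound 3, `O=C(NC(=S)NNc1ncnc2ccccc12)c1cccc(Cl)c1`, differs from compound 2 in one place: 3-chlorophenyl in place of 4-fluorophenyl on a carbonyl carbon. Going by the values given here, the one measured step also changed the aryl group on this carbonyl carbon, yet it replaced a 2-methoxyphenyl by a 4-fluorophenyl, whereas here one halogen-bearing ring is traded for another. That step therefore offers little guide to the size of this one, and the fact that compound 2 and compound 3 both carry a halophenyl on the carbonyl carbon points to a change within the scatter in this assay. The step expected from this reasoning is a 1.1-fold higher number from compound 2 to compound 3 (0.03 log units; within the scatter). Compound 3 is estimated at 2000 nM, with a range from 700 nM to 6000 nM.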

Compound 3, half-maximal inhibitory concentration: 4740 nM
For compound 3 the middle estimate is 2.4-fold (0.37 log units) below the measured one, within the range that was stated.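

Trading one halogen-bearing ring for another on this carbonyl carbon still registers in this assay, with a 2.5-fold higher number from compound 2 to compound 3 (0.40 log units; beyond the scatter), so keeping a halophenyl here does not leave the number unchanged. The step from the 2-methoxyphenyl compound remains large for this second halophenyl, at an at least 10-fold lower number from compound 1 to compound 3 (1.02 log units; beyond the scatter), which means that among the three compounds the swap away from 2-methoxyphenyl moves the number much more than the swap between the two halophenyl groups. The full size of that large step stays open, and compound 1 counts here only as a limit: the limit of > 50000 nM in this assay, at which 1 of the 3 values shown sits.

The step from compound 2 to compound 3 changes both the halogen and its numbered ring position at once, so the compounds shown cannot tell which of the two accounts for it, and a 4-chlorophenyl or a 3-fluorophenyl group on this carbonyl carbon would pull those two apart. On these data alone, it also remains open how this position would respond to a ring carrying something quite different from a halogen or methoxy group, such as an amine or a carboxylic acid.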